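Ethoxy for hydrogen on the pyrazine hydrazone: a cytotoxicity forecast

The compounds below may be only part of what the source reports. "The series", "measured", "known", "first", "only" and "open" are said of these compounds alone.

Three compounds have been measured in an ADME assay on J774 cells (Mus musculus) for cytotoxicity, read by MTT assay, with a stated time of 48 h, tested at 50 ug/mL; a higher number here means a weaker effect of the compound at the concentration tested, a lower number a stronger effect:

compound 1 `O=C(N/N=C/c1ccccc1)c1cnccn1` gives 100%
compound 2 `O=C(N/N=C/c1ccccc1Br)c1cnccn1` gives 98%
compound 3 `O=C(N/N=C/c1cccc(Br)c1)c1cnccn1` gives 100%

Compound 1 is level with compound 3 at the digits shown, and the two together are the highest of the three numbers; compound 2 is the furthest from compound 1, yet still within the scatter. The two measured steps both replace hydrogen with bromo on an aromatic carbon of the shared core: a number 2 percentage points lower from compound 1 to compound 2 (within the scatter) and no change at the digits printed from compound 1 to compound 3 (within the scatter). Neither step moves the read-out beyond the scatter.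

Compound 4 `CCOc1ccc(/C=N/NC(=O)c2cnccn2)cc1` is not yet measured. It differs from compound 1 by ethoxy in place of hydrogen on an aromatic carbon. The measured steps bear on it only loosely, since they introduce bromo rather than ethoxy, but both show that a substituent entering the same ring leaves this assay unchanged within the scatter. The expectation is therefore a step of a number 3 percentage points lower from compound 1 to compound 4 (within the scatter), that is, no movement beyond the scatter, because compound 1 stands at 100% and the ring already tolerates substitution. Compound 4 is expected to give 97%, with a range from 85% to 102%.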

Compound 4, a percentage reported as activity, at one concentration (the size of the read-out at that concentration, not a potency): 100%
For compound 4 the middle estimate is 3 percentage points below the measured one; the measured number falls inside the stated range.
By their numbers in this assay, from the lowest: compounds 2, 1, 3 and 4 (each within the scatter of the next).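

With ethoxy entering para to a large group, the result is no change at the digits printed from compound 1 to compound 4 (within the scatter) in this assay. The earlier steps shown here showed a flat read-out only for bromo, whereas this step shows the same for a group of 3 heavy atoms with 1 hydrogen-bond acceptor, at this place on the ring. Nothing available gives a cause for this flat result.

The compounds shown leave open whether the read-out would stay flat with an amine, a carboxylic acid or a longer chain such as butoxy at this place, and whether ethoxy would behave in the same way on the other carbons of this ring. With only a single tested concentration, they also leave open whether compound 1 and compound 4 would separate at a higher concentration.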